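Sulfonyl in place of a thioether on the shared core

The source may hold more compounds than are shown below. What is called first, only, known or untested is meant among the compounds shown, and "the series" means these compounds.

Measured compounds:
compound 1 `CCCCCCSc1nnc(COc2cc(C)c3c(C)cc(=O)oc3c2)o1` in a functional assay on MDA-MB-231 cells (Homo sapiens) for antiproliferative activity, read by MTT assay, with a stated time of 24 h (a higher number here means a weaker inhibitor, a lower number a stronger inhibitor), gives only a limit of > 100000 nM.
compound 2 `Cc1cc(OCc2nnc(SCc3ccccc3)o2)cc2oc(=O)cc(C)c12` in this assay gives only a limit of > 100000 nM.
compound 3 `CCS(=O)(=O)c1nnc(COc2cc(C)c3c(C)cc(=O)oc3c2)o1` in this assay gives only a limit of > 100000 nM.

Within the data shown here, compound 2 therefore stands not at a number but at a limit of this assay, and the two other values shown are limits as well, so no compound can be placed above or below another. The three steps between them, a step that the two limits leave unreadable from compound 1 to compound 2, a step that the two limits leave unreadable from compound 1 to compound 3 and a step that the two limits leave unreadable from compound 2 to compound 3, are all unreadable for the same reason, as the limit of > 100000 nM in this assay, at which 3 of the 3 values shown sit, shows.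

Compound 4 `CCCS(=O)(=O)c1nnc(COc2cc(C)c3c(C)cc(=O)oc3c2)o1` has not yet been measured in this assay. Its change from compound 2 is propylsulfonyl in place of benzylsulfanyl on an aromatic carbon. Among the measured compounds shown here, the nearest measured step is the one from compound 2 to compound 3, in which an ethylsulfonyl also replaced the benzylsulfanyl and compound 3 still sat at the limit. The expectation is therefore that compound 4 stays at the limit too, with a step that the limit leaves unreadable from compound 2 to compound 4 that cannot be read as a gain or a loss. The estimate for compound 4 is 150000 nM, within a range from 50000 nM to 500000 nM.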

Compound 4, half-maximal inhibitory concentration: 7070 nM
For compound 4 the middle estimate is 21-fold (1.33 log units) above the measured one; measured number outside the range, below it.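

In this assay, this position on the shared core can carry a group that gives a measurable number, but a sulfonyl alone does not ensure this: compound 3, with ethylsulfonyl, stays at the limit, and a single added methyl on that chain gives an at least 14-fold lower number from compound 3 to compound 4 (1.15 log units; beyond the scatter). Replacing either thioether with propylsulfonyl gives a step of similar printed size, an at least 14-fold lower number from compound 2 to compound 4 (1.15 log units; beyond the scatter) and an at least 14-fold lower number from compound 1 to compound 4 (1.15 log units; beyond the scatter). All three steps are minimum sizes, and their true sizes stay unknown because each starts from a limit: the limit of > 100000 nM in this assay, at which 3 of the 4 values shown sit.

From the compounds shown here alone, it remains open whether a butylsulfonyl group or a longer chain on the sulfonyl would lower the number further. A propylsulfanyl group at this position would be needed to show how much of the change from the thioethers belongs to the sulfonyl and how much to the propyl chain.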